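A few compounds are considered here, and "the series" means these few. Any claim that something is new, unique, unknown or untested is made for them only; others in the source may bear on it.

In a functional assay on 786-0 cells (Homo sapiens) for inhibition, read by sulforhodamine B assay, with a stated time of 48 h (on this read-out higher numbers stand for weaker inhibition of growth and lower numbers for stronger inhibition of growth), the measured compounds give the following:

Compound 1 `Ic1ccc(Cn2cc(CCCOc3cccc4cccnc34)nn2)cc1`: 22.6 ug/mL
Compound 2 `Fc1ccc(Cn2cc(CCCOc3cccc4cccnc34)nn2)cc1F`: 8.5 ug/mL
Compound 3 `Clc1ccc(Br)cc1Cn1cc(CCCOc2cccc3cccnc23)nn1`: > 250 ug/mL, which is a limit of the assay and not a number.

Among the two numbers, compound 1 stands highest; the step of a 2.7-fold lower number from compound 1 to compound 2 (0.42 log units; beyond the scatter) is modest but beyond the scatter. Compound 4 `c1cncc(CCCn2cc(CCCOc3cccc4cccnc34)nn2)c1` differs from compound 1 in one place: 2-(pyridin-3-yl)ethyl in place of 4-iodophenyl on a saturated chain carbon bound to an aromatic nitrogen. For the measured compounds named here, two measured steps touch the same place. Swapping the 4-iodophenyl for 3,4-difluorophenyl gave a 2.7-fold lower number from compound 1 to compound 2 (0.42 log units; beyond the scatter); swapping it for 5-bromo-2-chlorophenyl gave an at least 11-fold higher number from compound 1 to compound 3 (1.04 log units; beyond the scatter), ending at a limit. The group in this place therefore moves the result in either direction, by a modest or a large amount. Going by the values given here, compound 4 carries a chain-extended heteroaryl group, unlike any measured compound, so no step here resembles it closely. A step of a 1.8-fold higher number from compound 1 to compound 4 (0.25 log units; within the scatter) is expected, toward weaker inhibition, with wide uncertainty. For compound 4 the estimate in this assay is 40 ug/mL, expected between 10 ug/mL and 160 ug/mL.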

Compound 4, concentration for 50% growth inhibition: 69.4 ug/mL
Compound 4: the middle estimate sits 1.7-fold (0.24 log units) below what was measured; the measured number falls inside the stated range.
By their numbers in this assay, from the lowest: compound 2; then compound 1; then compound 4. At a limit, above all of these: compound 3.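

Compound 4 shows that this place accepts a 3-(pyridin-3-yl)propyl group, with a nitrogen in its ring and a longer chain, in place of the halogen-bearing benzyl groups, but growth inhibition weakens, with a 3.1-fold higher number from compound 1 to compound 4 (0.49 log units; beyond the scatter) and an 8.2-fold higher number from compound 2 to compound 4 (0.91 log units; beyond the scatter). Compound 3 stands at a limit of the assay and not at a number: the limit of > 250 ug/mL in this assay, at which 1 of the 4 values shown sits. Against that limit the step reads an at least 3.6-fold lower number from compound 3 to compound 4 (0.55 log units; beyond the scatter), so the change to the 2-(pyridin-3-yl)ethyl group does not lose as much as the change to 5-bromo-2-chlorophenyl does.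

Compound 4 changes the ring and the chain length at once, so the compounds shown cannot tell which of the two goes with the weaker inhibition. A 3-phenylpropyl group or a pyridin-3-ylmethyl group in the same place would separate the two.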